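The source may report more compounds than this note shows. Statements on the series, on what has been measured and on what is new or still open speak of the compounds shown alone.

Compound 3 `COc1ccc(NC(=O)COc2ccccc2)c(C(N)=O)c1` stands highest of the three measured compounds in a functional assay on K562 cells (Homo sapiens) for inhibition, read by trypan blue exclusion, with a stated time of 24 h, tested at 10 uM (a lower number here means less inhibition of growth, a higher number more inhibition of growth at the concentration tested), at 85.3%, ahead of compound 2 `Cc1ccc(OCC(=O)Nc2ccc(I)cc2C(N)=O)cc1` at 49.8% and compound 1 `Cc1ccc(OCC(=O)Nc2ccc(Cl)cc2C(N)=O)cc1` at 24.1%. Compound 4 `COc1ccc(NC(=O)COc2ccc(C)cc2)c(C(N)=O)c1` has methyl in place of hydrogen on an aromatic carbon. Among the compounds with values here, no measured step covers this change. The only one, a number 25.7 percentage points higher from compound 1 to compound 2 (beyond the scatter), is iodo in place of chloro, and it shows only that a single substitution can move this number modestly. Compound 2 already carries 4-methylphenyl and gives 49.8%, but it also differs from compound 3 in a second place, so it supports only a cautious expectation of a modest fall. The expected step of a number 17.3 percentage points lower from compound 3 to compound 4 (beyond the scatter) is downward. For compound 4 the estimated value is 68%, with an expected range of 42% to 90%.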

Compound 4, percent growth inhibition at one concentration: 48.1%
The estimate for compound 4 lay 19.9 percentage points above the measured number, within the range that was stated.
By their numbers in this assay, from the lowest: compound 1; then compounds 4 and 2 (each within the scatter of the next); then compound 3.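

In this assay, within the data shown here, the step of a number 37.2 percentage points lower from compound 3 to compound 4 (beyond the scatter) is the first direct reading of this position: with methoxy held constant, 4-methylphenyl in place of phenyl costs much of the growth inhibition. With 4-methylphenyl held constant, the step of a number 1.7 percentage points lower from compound 2 to compound 4 (within the scatter) leaves methoxy and iodo unseparated, whereas the step of a number 24 percentage points higher from compound 1 to compound 4 (beyond the scatter) sets methoxy apart from chloro. No measurement on hand accounts for these steps.

Going by these compounds, whether the fall extends to an amine, a carboxylic acid or a longer chain at this place remains open. Also open, on these data alone, is whether it recurs with chloro or iodo in place of methoxy.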